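Fluoro on the pyridine-type ring: thiosemicarbazide series notes

The source may hold more compounds than are shown below. What is called first, only, known or untested is meant among the compounds shown, and "the series" means these compounds.

Measured so far in a functional assay on MCF7 cells (Homo sapiens) for cytotoxicity, read by MTT assay, with a stated time of 72 h, tested at 100 uM; on this read-out higher numbers stand for more inhibition of growth at the one concentration tested and lower numbers for less inhibition of growth:
- compound 1, `N/C(=N\NC(=S)N1CCCCCC1)c1ccccn1`, 84%
- compound 2, `N/C(=N\NC(=S)N1CCSCC1)c1ccccn1`, 72.4%
- compound 3, `N/C(=N\NC(=S)N1CCSCC1)c1ccc(F)cn1`, 65.7%

Compound 1 stands highest of the three, and its gaps to compound 2 and to compound 3 lie beyond the scatter. The difference between the core of compound 1 and the core of compound 2 is not broken down here. Within the core of compound 2, the change fluoro in place of hydrogen on an aromatic carbon gives a number 6.7 percentage points lower from compound 2 to compound 3 (within the scatter), a step that stays within the scatter.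

Compound 4, `N/C(=N\NC(=S)N1CCCCCC1)c1ccc(F)cn1`, is not yet measured. It carries the same change on the core of compound 1: fluoro in place of hydrogen on an aromatic carbon. Because a number 6.7 percentage points lower from compound 2 to compound 3 (within the scatter) was small, the step is expected to be about a number 6 percentage points lower from compound 1 to compound 4 (within the scatter), resting on that one pair alone. Compound 4 is therefore estimated at 78%, between 66% and 89%.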

Compound 4, percent growth inhibition at one concentration: 79%
Estimate against measurement, compound 4: 1 percentage points below; low and high end bracket the measured number.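

On the second core, fluoro in place of hydrogen on an aromatic carbon gives a number 5 percentage points lower from compound 1 to compound 4 (within the scatter). In this assay, the change carries across the two cores shown with no difference in the size of the step: the same change on two cores in this assay, a number 6.7 percentage points lower (within the scatter) from compound 2 to compound 3 and a number 5 percentage points lower (within the scatter) from compound 1 to compound 4, 1.7 percentage points apart, within the scatter of two such steps

Two pairs read at one concentration do not show that the change has a real effect on either core, nor that it would behave the same way on any other core.

The compounds shown leave open whether another group in the same place, such as chloro, methoxy or nitrile, would give a step beyond the scatter. As far as these compounds go, an amine or a carboxylic acid there also remains open.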